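This account rests on a few compounds, and the source may have more. Where it says the series, first, only, none or still open, it means among the compounds named here.

In a functional assay on MCF7 cells (Homo sapiens) for cytotoxicity, read by sulforhodamine B assay, with a stated time of 48 h (on this read-out higher numbers stand for weaker inhibition and lower numbers for stronger inhibition), compound 1 `CC(=O)OC[C@H]1O[C@@H](n2cc(CN3C(=O)/C(=C/c4ccc(C)cc4)c4ccccc43)nn2)[C@H](OC(C)=O)[C@@H](OC(C)=O)[C@@H]1OC(C)=O` gives only a limit, > 100000 nM. Compound 2 `CC(=O)OC[C@H]1O[C@@H](n2cc(CN3C(=O)/C(=C\c4ccc(C)cc4)c4ccccc43)nn2)[C@H](OC(C)=O)[C@@H](OC(C)=O)[C@@H]1OC(C)=O`, which has the same atoms and bonds and differs only in the configuration as drawn of one double bond, also gives only a limit in this assay, > 100000 nM. Among the compounds with values here, the step that the two limits leave unreadable from compound 1 to compound 2 is therefore unreadable because of the limit of > 100000 nM in this assay, at which 2 of the 2 values shown sit; the sole structural change behind it is the fact that compounds 1 and 2 differ only in the configuration as drawn. Compound 2 thus stands at the limit, with nothing in the known numbers to place it more closely. Compound 3 `CC(=O)OC[C@H]1O[C@@H](n2cc(CN3C(=O)/C(=C\C=C\c4ccccc4)c4ccccc43)nn2)[C@H](OC(C)=O)[C@@H](OC(C)=O)[C@@H]1OC(C)=O` is obtained from compound 2 by 2-phenylethenyl in place of 4-methylphenyl on a double-bonded chain carbon bound to a double-bonded ring carbon. Within the data shown here, no measured step bears directly on this change: the only step known, a step that the two limits leave unreadable from compound 1 to compound 2, is unreadable and concerns a different kind of change. With both known compounds sitting at the same limit, the expected step of a number no higher from compound 2 to compound 3 (the limit leaves the size open) in this assay is none beyond the scatter. Compound 3 is accordingly estimated at 100000 nM, between 30000 nM and 300000 nM, with a real chance that only a limit is again reported.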

Compound 3, half-maximal inhibitory concentration: 34100 nM
For compound 3 the middle estimate is 2.9-fold (0.47 log units) above the measured one; the range from low to high includes it.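

Within the data shown here, compound 3 gives the first value in this assay that is a number and not a limit, so this place, on a double-bonded chain carbon bound to a double-bonded ring carbon, proves able to move the read-out. Putting 2-phenylethenyl in place of 4-methylphenyl gives an at least 2.9-fold lower number from compound 2 to compound 3 (0.46 log units; beyond the scatter), with the one six-membered aromatic ring of carbon kept and a double bond outside aromatic rings added. The size of this step is only a lower bound, and it may be larger, because one end of it rests on a limit: the limit of > 100000 nM in this assay, at which 2 of the 3 values shown sit.

Among these compounds, the single step on configuration as drawn cannot be read, so whether the drawn double bond matters at this place remains open, as does whether the step comes from the added double bond or from the loss of the methyl group. Going by these compounds, it is also open how this assay would read with a longer chain, or with an amine or a carboxylic acid, at this place.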